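The compounds below may be only part of what the source reports. "The series", "measured", "known", "first", "only" and "open" are said of these compounds alone.

In a functional assay on MCF7 cells (Homo sapiens) for cytotoxicity, read by ELISA, with a stated time of 4 days (a lower number here means a stronger inhibitor, a higher number a weaker inhibitor), three compounds on a shared core have been measured. Compound 1 `Cc1ccsc1-c1cc(-c2ccco2)cc(-c2ccc(Cl)cc2)n1` gives 890 nM and compound 2 `Cc1ccsc1-c1cc(-c2ccoc2)cc(-c2ccco2)n1` gives 18300 nM there. Compound 3 `Cc1ccc(-c2cc(-c3ccoc3)cc(-c3ccc(Cl)s3)n2)o1` gives 1900 nM and so stands second highest of the three numbers, higher than compound 1 and lower than compound 2, with both gaps beyond the scatter. Compound 4 `Clc1ccc(-c2cc(-c3ccoc3)cc(-c3ccccn3)n2)s1` differs from compound 3 in one place (pyridin-2-yl in place of 5-methylfuran-2-yl on an aromatic carbon): pyridin-2-yl in place of 5-methylfuran-2-yl on an aromatic carbon. Within the data shown here, no measured pair shows this change, so in this assay only a small upward step, within the scatter, is expected (a 1.3-fold higher number from compound 3 to compound 4 (0.12 log units; within the scatter)). Compound 4 is expected to give about 2500 nM with an estimated range from 800 nM to 8000 nM as its plausible span.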

Compound 4, half-maximal inhibitory concentration: 3360 nM
Compound 4: middle estimate off by 1.3-fold (0.13 log units), on the low side, and the stated range covers the measured number.
By their numbers in this assay, from the lowest: compound 1; then compounds 3 and 4 (each within the scatter of the next); then compound 2.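

Among these compounds, this pair is the first one-place comparison on the shared core. In this assay the exchange of 5-methylfuran-2-yl for pyridin-2-yl gives a 1.8-fold higher number from compound 3 to compound 4 (0.25 log units; within the scatter) and so leaves the number within the scatter, with the five-membered and six-membered aromatic rings not told apart at this position next to the ring nitrogen. Nothing available explains this result. Going by these compounds, it remains open whether an amine, a carboxylic acid or a longer chain at this position would move the number beyond the scatter. On these data alone, whether the exchange behaves alike without the 5-chlorothiophen-2-yl group also remains open.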